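Swapping the benzyl halogen on a covalent thiazolidinedione

The source may report more compounds than this note shows. Statements on the series, on what has been measured and on what is new or still open speak of the compounds shown alone.

Measured so far:
compound 1, `C=C(Br)C(=O)Nc1cccc(/C=C2\SC(=O)N(Cc3ccc(Cl)cc3)C2=O)c1`: 1400 nM
compound 2, `Nc1ccc(/C=C2\SC(=O)N(Cc3ccc(F)cc3)C2=O)cc1`: 111000 nM

In a functional assay on CCRF-CEM cells (Homo sapiens) for cytotoxicity, read by cell counting, with a stated time of 3 days (a higher number here means a weaker inhibitor, a lower number a stronger inhibitor), compound 1 gives 1400 nM, the lower of the two numbers and therefore the stronger inhibitor here. Compound 2 gives 111000 nM, a far higher number, and this gap lies well beyond the scatter of the method; compound 2 differs from compound 1 in more than one place, so no single cause can be read from it.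

Compound 3, `C=C(Br)C(=O)Nc1cccc(/C=C2\SC(=O)N(Cc3cccc(F)c3)C2=O)c1`, is not yet measured. It keeps the whole of compound 1 except for one change: 3-fluorophenyl in place of 4-chlorophenyl on a saturated chain carbon bound to an amide-type nitrogen in a ring. The group that leaves and the group that enters are both halogen-bearing phenyls of the same size, with no donors or acceptors either way. Among the compounds with values here, with no measured step of this kind to lean on, the expected step of a 1.4-fold higher number from compound 1 to compound 3 (0.15 log units; within the scatter) is small, within or close to the usual scatter. Compound 3 is thus expected to give about 2000 nM, plausibly between 700 nM and 6000 nM.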

Compound 3, half-maximal inhibitory concentration: 690 nM
Beside the measured number, compound 3's estimate is 2.9-fold (0.46 log units) above it; measured number outside the range, below it.
By their numbers in this assay, from the lowest: compound 3; then compound 1; then compound 2.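

The site on a saturated chain carbon bound to an amide-type nitrogen in a ring can take a different halogen-bearing phenyl without losing activity. In this assay, placing 3-fluorophenyl where 4-chlorophenyl stood gives a 2.0-fold lower number from compound 1 to compound 3 (0.31 log units; beyond the scatter), a modest gain in strength. Within the data shown here, this is the first step here that changes only one place, so the difference can be assigned to that swap of groups rather than to several changes at once, although nothing available explains why the number moves.

Going by these compounds, the halogen and its place on the phenyl changed together, so the effect of each alone stays unknown; 3-chlorophenyl on the core of compound 1 would help separate them. On these data alone, how this site responds to a phenyl carrying an amine or a carboxylic acid also remains open.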